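Reversing a chloro-to-methoxy swap on the benzyl group

The source may hold more compounds than are shown below. What is called first, only, known or untested is meant among the compounds shown, and "the series" means these compounds.

Compound 1 `COc1ccc(Cn2cc(/C=N\NC(=O)c3c[nH]c4ccc(Br)cc34)c3cc(OC)ccc32)cc1` gives 3100 nM in a functional assay on MCF7 cells (Homo sapiens) for cytotoxicity; on this read-out lower numbers stand for stronger inhibition and higher numbers for weaker inhibition.
Compound 2 `COc1ccc2c(c1)c(/C=N\NC(=O)c1c[nH]c3ccc(Br)cc13)cn2Cc1ccc(Cl)cc1` gives 29100 nM in this assay.
Compound 3 `Cn1cc(C(=O)N/N=C\c2cn(Cc3ccc(Cl)cc3)c3cc(F)ccc23)c2ccccc21` gives 90600 nM in this assay.

Compound 3 stands at the highest number of the three in this assay, beyond the scatter from both compound 2 and compound 1. Compound 4 `COc1ccc(Cn2cc(/C=N\NC(=O)c3cn(C)c4ccccc34)c3ccc(F)cc32)cc1` differs from compound 3 by methoxy in place of chloro on an aromatic carbon. Among the compounds with values here, one measured step bears directly on this change, in the opposite direction: a 9.4-fold higher number from compound 1 to compound 2 (0.97 log units; beyond the scatter). That pair carries a different core than compound 3, so the size may not transfer exactly, but the direction suggests that putting methoxy back in place of chloro should move the number down, and by more than the scatter. On that basis the number for compound 4 is expected to fall by roughly a 6.0-fold lower number from compound 3 to compound 4 (0.78 log units; beyond the scatter). The estimate for compound 4 in this assay is therefore 15000 nM, with a likely range from 4000 nM to 50000 nM.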

Compound 4, half-maximal inhibitory concentration: 22600 nM
Compound 4: middle estimate off by 1.5-fold (0.18 log units), on the low side, and the stated range covers the measured number.
By their numbers in this assay, from the lowest: compound 1; then compounds 4 and 2 (each within the scatter of the next); then compound 3.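

Measured in this assay the change from 4-chlorobenzyl to 4-methoxybenzyl gives a 4.0-fold lower number from compound 3 to compound 4 (0.60 log units; beyond the scatter) on the core of compound 3, so the swap now has a reading on a second core. Where compounds 1 and 2 gave only one reading of this change, the methoxy compound now carries the lower number in both pairs, and neither pair goes against that direction. The two sizes cannot be told apart: the same change on two cores in this assay, a 9.4-fold higher number (0.97 log units; beyond the scatter) from compound 1 to compound 2 and a 4.0-fold higher number (0.60 log units; beyond the scatter) from compound 4 to compound 3, 2.3-fold (0.37 log units) apart, within the scatter of two such steps

The compounds shown carry only chloro or methoxy at this place, para to a large group, so they leave open how an amine, a hydroxyl or a nitrile there would read. From the compounds shown here alone, whether the same direction holds on any core beyond these two also stays open, since two pairs are all that bear on it.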